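Trading an amide for a hydroxybutyl chain

The compounds below may be only part of what the source reports. "The series", "measured", "known", "first", "only" and "open" are said of these compounds alone.

Measured so far:
- Compound 1 `COc1ccccc1-c1cnc(N)nc1-c1ccccc1` gives 20% in an assay on CHO cells for displacement of a labelled ligand from adenosine receptor A1 (Homo sapiens), read by scintillation counting, with a stated time of 1 h, tested at 1 uM; on this read-out lower numbers stand for less inhibition and higher numbers for more inhibition at the one concentration tested (going by the name of the read-out).
- Compound 2 `COc1ccc(-c2cnc(N)nc2-c2ccccc2)cc1OC` sits at a limit of this assay, reported as > 80%.
- Compound 3 `O=C(Nc1ncc(-c2cccc(Cl)c2)c(-c2ccccc2)n1)C1CCCC1` gives 47% in this assay.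

Among the two plain numbers, compound 3 stands highest; its nearest neighbour, compound 1, lies lower by a gap that is beyond the usual scatter of repeated measurements. Compound 2 is a different case: it sits at the limit of > 80% in this assay, at which 1 of the 3 values shown sits, so its value is a limit rather than a number and cannot be ranked against the others.

Compound 4 `OCCCCNc1ncc(-c2cccc(Cl)c2)c(-c2ccccc2)n1` has not yet been measured. It differs from compound 3 in one place:

4-hydroxybutyl in place of cyclopentylcarbonyl on a nitrogen on an aromatic ring

Among the compounds with values here, no measured pair shows a change of this kind, so the size of the step can only be estimated. In this assay a modest fall is expected, with considerable uncertainty. Compound 4 is expected to give 35%, in a range from 10% to 65%. The expected step is a number 12 percentage points lower from compound 3 to compound 4 (beyond the scatter).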

Compound 4, a percentage reported as inhibition, at one concentration (the size of the read-out at that concentration, not a potency): > 80%
Compound 4: a limit, no number; the forecaster's own chance of this, stated with the estimate: 5%; at least 45 percentage points between middle value and limit.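

On the nitrogen on an aromatic ring, swapping cyclopentylcarbonyl for 4-hydroxybutyl gives a number at least 33 percentage points higher from compound 3 to compound 4 (beyond the scatter). So in this assay, neither the carbonyl nor the five-membered ring is needed at this position for a high reading on this core, and this place responds strongly to what is attached there. The value of compound 4 is a limit, not a number, so the full size of the step stays unknown: the limit of > 80% in this assay, at which 2 of the 4 values shown sit.

The change removes a carbonyl and a ring and adds a hydroxyl all at once, so the compounds shown leave open which of these matters. A plain butyl chain, a cyclopentyl group directly on the nitrogen, or a chain ending in an amine or a carboxylic acid would help pull these parts apart.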